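Swapping furan-2-yl for cyclohexyloxy on compound 3

The compounds below may be only part of what the source reports. "The series", "measured", "known", "first", "only" and "open" are said of these compounds alone.

Of the compounds shown here, three have been measured in a functional assay for inhibition of sodium/hydrogen exchanger (Oryctolagus cuniculus); on this read-out lower numbers stand for stronger inhibition and higher numbers for weaker inhibition. Compound 1 `CS(=O)(=O)c1cc(C(=O)N=C(N)N)c(F)cc1F` gives 630 nM, compound 2 `Cc1cc(Br)c(C(=O)N=C(N)N)cc1S(C)(=O)=O` gives 70 nM, and compound 3 `Cc1cc(-c2ccco2)c(S(C)(=O)=O)cc1C(=O)N=C(N)N` gives 16 nM. Compound 3 therefore has the lowest number of the three; the gap to compound 2, its nearest neighbour, and the wider gap to compound 1 both lie beyond the scatter, so compound 3 is the strongest inhibitor measured so far. Compound 4 `Cc1cc(OC2CCCCC2)c(S(C)(=O)=O)cc1C(=O)N=C(N)N` differs from compound 3 in one place: cyclohexyloxy in place of furan-2-yl on an aromatic carbon. Among the measured compounds shown here, no measured pair shows the effect of such a change, so the expected step of a 1.9-fold higher number from compound 3 to compound 4 (0.27 log units; within the scatter) is small, leaning toward weaker inhibition but not clearly beyond the scatter. Compound 4 is therefore estimated at 30 nM, with a range from 8 nM to 120 nM.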

Compound 4, half-maximal inhibitory concentration: 37 nM
The estimate for compound 4 lay 1.2-fold (0.09 log units) below the measured number; low and high end bracket the measured number.
By their numbers in this assay, from the lowest: compound 3; then compounds 4 and 2 (each within the scatter of the next); then compound 1.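

In this assay, exchanging furan-2-yl for cyclohexyloxy, ortho to the methylsulfonyl group, gives a 2.3-fold higher number from compound 3 to compound 4 (0.36 log units; beyond the scatter). The step is modest: this position accepts a non-aromatic carbon ring held through oxygen, with some loss of inhibition but with inhibition still clear. Nothing measured here accounts for the size or direction of this step. From the compounds shown here alone, the two groups differ both in the oxygen link and in aromatic character, and it remains open which of these matters. Phenoxy or a directly attached cyclohexyl group would separate the two.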